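The source may report more compounds than this note shows. Statements on the series, on what has been measured and on what is new or still open speak of the compounds shown alone.

Measured so far in a physicochemical assay for lipophilicity, read by HPLC, measured as octanol-water partition; on this read-out lower numbers stand for lower lipophilicity and higher numbers for higher lipophilicity:
compound 1 `O=C1O[C@@H](CO)CN1c1ccc(-n2cc(-c3ccccn3)cn2)c(F)c1` gives 1.67
compound 2 `CC(=O)OC[C@H]1CN(c2ccc(-n3cc(-c4ccccn4)cn3)c(F)c2)C(=O)O1` gives 2.09

Among the measured compounds shown here, compound 2 stands highest of the two numbers so far in this assay, with compound 1 as its only neighbour. For the measured compounds named here, the one measured step, a number 0.42 log units higher from compound 1 to compound 2 (beyond the scatter), is modest but beyond the scatter; it comes from acetyl in place of hydrogen on an oxygen on a saturated carbon.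

Compound 3 `O=C1O[C@@H](CSc2cccs2)CN1c1ccc(-n2cc(-c3ccccn3)cn2)c(F)c1` has not yet been measured in this assay. Its difference from compound 2 is (thiophen-2-yl)sulfanyl in place of acetoxy on a saturated chain carbon bound to a saturated ring carbon, or, cut one bond further out, acetoxymethyl to ((thiophen-2-yl)sulfanyl)methyl. The step from compound 1 to compound 2 bears on this only loosely, since it shows that a change at the same position moved the number upward beyond the scatter. The present change is larger in what enters, as the difference shows, so a larger upward step is expected in this assay. For compound 3 the expected step is a number 1.51 log units higher from compound 2 to compound 3 (beyond the scatter). The estimate for compound 3 in this assay is 3.6, with a range from 3 to 4.2.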

Compound 3, partition coefficient: 4.29
Beside the measured number, compound 3's estimate is 0.69 log units below it; measured number outside the range, above it.
By their numbers in this assay, from the lowest: compound 1; then compound 2; then compound 3.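

In this assay, the place on a saturated chain carbon bound to a saturated ring carbon proves far more responsive than the acetyl change alone suggested: (thiophen-2-yl)sulfanyl in place of acetoxy gives a number 2.20 log units higher from compound 2 to compound 3 (beyond the scatter), and in place of hydroxy it gives a number 2.62 log units higher from compound 1 to compound 3 (beyond the scatter), both large. Set against the modest a number 0.42 log units higher from compound 1 to compound 2 (beyond the scatter), these steps show that the group entering here can shift the number much further than acetyl on the oxygen did, and the step from acetoxy comes with no change in the counts of hydrogen-bond donors or acceptors. Nothing on hand accounts for the size of these steps.

The sulfur link and the thiophene ring enter together, so the compounds shown do not tell how much of the step belongs to either. On these data alone, how phenylsulfanyl, an amine or a carboxylic acid on the same saturated chain carbon would read in this assay also remains open, as does whether such groups would fall nearer compound 1 or compound 3.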